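A shifted dimethoxyphenyl group on the shared core

The source may hold more compounds than are shown below. What is called first, only, known or untested is meant among the compounds shown, and "the series" means these compounds.

Measured in an ADME assay on cells (Lymphocyte, Homo sapiens) for cytotoxicity, read by MTT assay, with a stated time of 48 h; a lower number here means a stronger inhibitor, a higher number a weaker inhibitor:
- compound 1 `COC(=O)/C(=C\c1ccc(OC(=O)c2ccc(OC)cc2)cc1)Sc1ccnc2cc(Cl)ccc12`: 63500 nM
- compound 2 `COC(=O)/C(=C\c1ccc(OC(=O)c2cccc(OC)c2)cc1)Sc1ccnc2cc(Cl)ccc12`: > 100000 nM (a limit of the assay, not a number)
- compound 3 `COC(=O)/C(=C\c1ccc(OC(=O)c2ccc(OC)c(OC)c2)cc1)Sc1ccnc2cc(Cl)ccc12`: 51100 nM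

Compound 3 stands level with compound 1, the measured difference being a 1.2-fold lower number from compound 1 to compound 3 (0.09 log units; within the scatter). Compound 2 gives only a limit, so the data show just an at least 1.9-fold lower number from compound 2 to compound 3 (0.29 log units; that floor lies within the scatter).

Compound 4 `COC(=O)/C(=C\c1ccc(OC(=O)c2cccc(OC)c2OC)cc1)Sc1ccnc2cc(Cl)ccc12` carries 2,3-dimethoxyphenyl in place of 3,4-dimethoxyphenyl on a carbonyl carbon. Going by the values given here, the nearest precedent is 3-methoxyphenyl in place of 4-methoxyphenyl, which gave an at least 1.5-fold higher number from compound 1 to compound 2 (0.19 log units; that floor lies within the scatter). Adding methoxy in place of hydrogen gave the two steps above, and neither of them clears the scatter. So no step beyond the scatter is expected in this assay, only a lean towards a higher number because an at least 1.5-fold higher number from compound 1 to compound 2 (0.19 log units; that floor lies within the scatter) points that way. The expected step is a 1.4-fold higher number from compound 3 to compound 4 (0.14 log units; within the scatter). For compound 4 the estimate is 70000 nM, with an expected range from 38000 nM to 130000 nM.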

Compound 4, half-maximal inhibitory concentration: 86600 nM
The estimate for compound 4 lay 1.2-fold (0.09 log units) below the measured number; the measured number falls inside the stated range.
By their numbers in this assay, from the lowest: compounds 3, 1 and 4 (each within the scatter of the next). At a limit, above all of these: compound 2.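

In this assay, moving from 3,4-dimethoxyphenyl to 2,3-dimethoxyphenyl on this carbonyl carbon gives a 1.7-fold higher number from compound 3 to compound 4 (0.23 log units; within the scatter) and so stays inside the usual scatter, which means this new arrangement of the two methoxy groups makes no measurable difference here. Replacing the 4-methoxyphenyl group of compound 1 with 2,3-dimethoxyphenyl gives a 1.4-fold higher number from compound 1 to compound 4 (0.13 log units; within the scatter) and is likewise too small to read as a change. Compound 2 gives only a limit of the assay, not a number, so the comparison with it yields just an at least 1.1-fold lower number from compound 2 to compound 4 (0.06 log units; that floor lies within the scatter) as a floor.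

Going by these compounds, all four compounds carry methoxy groups on this ring, so it remains open whether an amine or a carboxylic acid there would give a step beyond the scatter. How far compound 2 lies from the others also stays open: the limit of > 100000 nM in this assay, at which 1 of the 4 values shown sits.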